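Fluoro on compound 1: expected cytotoxicity

The source may report more compounds than this note shows. Statements on the series, on what has been measured and on what is new or still open speak of the compounds shown alone.

Among the compounds with values here, in a functional assay on B16-F10 cells (Mus musculus) for cytotoxicity, read by MTT assay, with a stated time of 48 h (a higher number here means a weaker inhibitor, a lower number a stronger inhibitor), compound 1 `Clc1cccc2sc(Nc3nc4ccccc4s3)nc12` gives 29500 nM, the only actual number so far. Compound 2 `Cc1ccc2nc(NC(=S)Nc3ccccc3)sc2c1` gives > 50000 nM, which is a limit. Compound 3 `c1ccc2sc(Nc3nc4ccccc4s3)nc2c1` gives > 50000 nM, which is also a limit. Compound 4 `Fc1ccc2nc(Nc3nc4c(Cl)cccc4s3)sc2c1` differs from compound 1 by fluoro in place of hydrogen on an aromatic carbon. Within the data shown here, the one measured step that bears on this is hydrogen in place of chloro, an at least 1.6-fold higher number from compound 1 to compound 3 (0.22 log units; that floor lies within the scatter), and it concerns a different place on the core. In this assay no change beyond the scatter is therefore expected, and the estimated step is a 1.1-fold lower number from compound 1 to compound 4 (0.02 log units; within the scatter). For compound 4 the expected value is 28000 nM, with an estimated range from 12000 nM to 50000 nM.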

Compound 4, half-maximal inhibitory concentration: > 50000 nM
Compound 4 gave a limit, no number; the forecaster's own chance of this, stated with the estimate: 30%; middle value at least 1.7-fold (0.25 log units) away from the limit.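

In this assay, fluoro in place of hydrogen on an aromatic carbon, meta to a fused ring and para to a fused ring, gives an at least 1.6-fold higher number from compound 1 to compound 4 (0.22 log units; that floor lies within the scatter). Compound 4 gives a limit rather than a number, and since the floor of the step lies within the scatter, this first change at this position shows no gain with fluoro and leaves any loss unsized. The comparison ends at the same limit as most of the series: the limit of > 50000 nM in this assay, at which 3 of the 4 values shown sit.

Going by these compounds, whether an amine or a carboxylic acid at this position would lower the number of compound 1 remains open. On these data alone, the true size of the step also remains open.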